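The source may report more compounds than this note shows. Statements on the series, on what has been measured and on what is new or still open speak of the compounds shown alone.

Working notes on the series, in an assay on CHO-K1 cells for antagonist activity at transient receptor potential cation channel subfamily V member 4 (Homo sapiens), read by FLIPR and calcium flux, with a stated time of 5 min; a higher number here means a weaker inhibitor, a lower number a stronger inhibitor. Of the compounds shown here, two have numbers so far. Compound 1 `N#Cc1ccc(S(=O)(=O)N2CCC(O)(COc3ccc(C#N)c(F)c3)CC2)c(Cl)c1` gives 49.1 nM in this assay. Compound 2 `N#Cc1ccc(OCC2(O)CN(S(=O)(=O)c3ccc(Cl)cc3C#N)C2)cc1F` gives 3.4 nM in this assay. Within the data shown here, compound 2 thus holds the lower of the two numbers, and the gap to compound 1 is beyond the scatter; no single-point step between compound 1 and compound 2 exists, so nothing more is read from that pair than the two values themselves.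

Compound 3 `N#Cc1ccc(OCC2(O)CN(S(=O)(=O)c3ccc(Cl)cc3C#N)C2)cc1Cl` has not been measured. It differs from compound 2 in one place: chloro in place of fluoro on an aromatic carbon, on an aromatic carbon ortho to a cyano group and meta to a large group. Among the measured compounds shown here, no measured pair shows this exchange, so its effect here is unknown. With only the number for compound 2 as anchor, the expectation is a step from compound 2 to compound 3 of a 1.3-fold higher number from compound 2 to compound 3 (0.12 log units; within the scatter), that is, no change beyond the usual scatter in either direction. Compound 3 is therefore estimated at 4.5 nM in this assay, within a range of 1.5 nM to 14 nM.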

Compound 3, half-maximal inhibitory concentration: 3.6 nM
Beside the measured number, compound 3's estimate is 1.3-fold (0.10 log units) above it, and the stated range covers the measured number.
By their numbers in this assay, from the lowest: compounds 2 and 3 (each within the scatter of the next); then compound 1.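

In this assay, the exchange of fluoro for chloro on an aromatic carbon ortho to a cyano group, which turns 4-cyano-3-fluorophenyl into 3-chloro-4-cyanophenyl, gives a 1.1-fold higher number from compound 2 to compound 3 (0.02 log units; within the scatter). This is the only single-point step among the compounds shown, and it indicates that on this core and at this position, the two halogens cannot be told apart in this assay: fluoro is not required for a value in the range of compound 2, and chloro serves equally well. No measurement at hand offers an explanation for why the two halogens read alike.

The compounds shown leave open whether this position accepts groups other than these two halogens, such as a methyl, a methoxy or an amine, or a bare hydrogen. Among these compounds, they also leave open whether the same exchange would read alike on the core of compound 1, since the step so far comes from a single pair on the core shared by compound 2 and compound 3.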